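Removing the trifluoromethyl from the weakest diaryl urea

This account rests on a few compounds, and the source may have more. Where it says the series, first, only, none or still open, it means among the compounds named here.

In a functional assay on HT-29 cells (Homo sapiens) for antiproliferative activity, read by MTT assay, with a stated time of 48 h (on this read-out lower numbers stand for stronger inhibition and higher numbers for weaker inhibition), compound 1 `O=C(Nc1ccc(OC(=O)c2ccc(Cl)cc2)cc1)Nc1ccc(Cl)c(C(F)(F)F)c1` gives 8320 nM. Compound 2 `COc1ccc(C(=O)Oc2ccc(NC(=O)Nc3ccc(Cl)c(C(F)(F)F)c3)cc2)cc1` gives 33800 nM, and compound 3 `O=C(Nc1ccc(OC(=O)c2ccccc2)cc1)Nc1ccc(Cl)c(C(F)(F)F)c1` gives 151000 nM, the highest of the three numbers, since an 18-fold higher number from compound 1 to compound 3 (1.26 log units; beyond the scatter) and a 4.5-fold higher number from compound 2 to compound 3 (0.65 log units; beyond the scatter) both lie beyond the scatter. Compound 4 `O=C(Nc1ccc(Cl)cc1)Nc1ccc(OC(=O)c2ccccc2)cc1` differs from compound 3 by hydrogen in place of trifluoromethyl on an aromatic carbon. The measured steps, a 4.1-fold higher number from compound 1 to compound 2 (0.61 log units; beyond the scatter) together with the two just given, all change a group on a different ring from the one that here loses its trifluoromethyl, so none of them bears on this change, and its size cannot be read from them. With nothing to point to a gain, the expected step is a 1.7-fold higher number from compound 3 to compound 4 (0.22 log units; within the scatter), toward a weaker compound, with a wide range. Compound 4 is therefore estimated at 250000 nM, between 70000 nM and 900000 nM.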

Compound 4, half-maximal inhibitory concentration: 56000 nM
Compound 4: middle estimate off by 4.5-fold (0.65 log units), on the high side, and the stated range ends above it.
By their numbers in this assay, from the lowest: compound 1; then compounds 2 and 4 (each within the scatter of the next); then compound 3.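

In this assay, replacing the trifluoromethyl with hydrogen gives a 2.7-fold lower number from compound 3 to compound 4 (0.43 log units; beyond the scatter), so inhibition gets stronger when this group is lost. The earlier steps shown here all changed the other ring; this one shows that, at least in this pair, the trifluoromethyl ortho to a chloro group is not required for activity. Nothing measured here accounts for the gain.

From the compounds shown here alone, it remains open whether compound 1 and compound 2 would gain in the same way on losing their trifluoromethyl. Going by these compounds, how a methyl or an amine would compare with hydrogen at this position is also open.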